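Removing a fluoro group: from compound 2 to compound 4

A few compounds are considered here, and "the series" means these few. Any claim that something is new, unique, unknown or untested is made for them only; others in the source may bear on it.

Measured compounds:
compound 1 `COc1cc(OC)c(OC)cc1/C=C/C(=O)c1ccc(OC)c2c1OC(C)(C)C=C2`: > 10000 nM
compound 2 `COc1ccc(C(=O)/C=C/c2cccc(F)c2)c2c1C=CC(C)(C)O2`: > 10000 nM
compound 3 `COc1ccc(C(=O)/C=C/c2ccc3ccccc3n2)c2c1C=CC(C)(C)O2`: 3020 nM

In a functional assay on K562 cells (Homo sapiens) for antiproliferative activity, read by MTT assay, with a stated time of 24 h (a higher number here means a weaker inhibitor, a lower number a stronger inhibitor), compound 1 gives > 10000 nM, which is a limit and not a number. Compound 2 gives > 10000 nM in this assay, again a limit. Compound 3 gives 3020 nM in this assay and is the only compound shown with a number. On these data alone, compound 2 thus sits at the limit of > 10000 nM in this assay, at which 2 of the 3 values shown sit, and its true value is unknown beyond that.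

Compound 4 `COc1ccc(C(=O)/C=C/c2ccccc2)c2c1C=CC(C)(C)O2` differs from compound 2 by hydrogen in place of fluoro on an aromatic carbon. No measured pair isolates this change, so nothing among the shown values tells its size. Compound 4 is expected to stay near compound 2, with a step that the limit leaves unreadable from compound 2 to compound 4 expected to lie within the scatter and most likely to end again in a limit. The estimate for compound 4 in this assay is 15000 nM, in the range 5000 nM to 50000 nM.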

Compound 4, half-maximal inhibitory concentration: > 10000 nM
Compound 4 was reported as a limit; the forecaster's own chance of this, stated with the estimate: 70%; the middle value does not contradict the limit.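

Among these compounds, compound 2 and compound 4 both stand only as limits in this assay, and no step between them can be read. The compounds shown leave open whether hydrogen in place of fluoro changes activity at all.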